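The source may hold more compounds than are shown below. What is called first, only, known or untested is meant among the compounds shown, and "the series" means these compounds.

Compound 1 `Cc1cc(Sc2ccccc2)c(S(C)(=O)=O)cc1C(=O)N=C(N)N`: 14 nM
Compound 2 `Cc1cc(OCc2ccccc2)c(S(C)(=O)=O)cc1C(=O)N=C(N)N`: 28 nM

In a functional assay for inhibition of sodium/hydrogen exchanger (Oryctolagus cuniculus) (on this read-out lower numbers stand for stronger inhibition and higher numbers for weaker inhibition), compound 2 stands at the upper end of the two values measured, with compound 1 nearest; the step of a 2.0-fold higher number from compound 1 to compound 2 (0.30 log units; within the scatter) is within the scatter, so the two cannot be told apart. Compound 3 `Cc1cc(OC2CCCCC2)c(S(C)(=O)=O)cc1C(=O)N=C(N)N` differs from compound 2 in one place: cyclohexyl in place of benzyl on an oxygen on an aromatic ring. Within the data shown here, the only measured step, from compound 1 to compound 2, alters the link between the outer ring and the shared core rather than that ring itself, so no measured step bears directly on this change. A modest step of uncertain direction is therefore expected in this assay, a 2.1-fold higher number from compound 2 to compound 3 (0.33 log units; beyond the scatter). Compound 3 is expected to give about 60 nM, within 15 nM to 250 nM.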

Compound 3, half-maximal inhibitory concentration: 37 nM
Compound 3: the middle estimate sits 1.6-fold (0.21 log units) above what was measured; the measured number falls inside the stated range.
By their numbers in this assay, from the lowest: compounds 1, 2 and 3 (each within the scatter of the next, the first and the last beyond it).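

In this assay, cyclohexyl in place of benzyl on this oxygen gives a 1.3-fold higher number from compound 2 to compound 3 (0.12 log units; within the scatter), so for this pair a non-aromatic ring serves as well as an aromatic one. Compound 1 and compound 3 do separate, with a 2.6-fold higher number from compound 1 to compound 3 (0.42 log units; beyond the scatter), but that change alters both the link and the outer ring, so the compounds shown cannot assign the step to either alone. Nothing measured here explains these numbers. Still open, going by these compounds, is whether an amine or a carboxylic acid on the cyclohexyl ring, or a longer chain on this oxygen, would keep the number in this range.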